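The source may report more compounds than this note shows. Statements on the series, on what has been measured and on what is new or still open speak of the compounds shown alone.

Within the data shown here, compound 1 `COC(=O)C1=C(C)NC(=O)NC1c1ccc(O)cc1` is one of two compounds measured in a functional assay, read by spectrophotometry, in phosphate buffer, with a stated time of 10 min, at pH 6.6; on this read-out higher numbers stand for an effect only at larger amounts of compound and lower numbers for an effect already at smaller amounts. In this assay compound 1 gives 67 ug/mL. Its nearest neighbour is compound 2 `COC(=O)C1=C(C)NC(=O)NC1c1ccc(O)c(OC)c1`, which in this assay gives 57.1 ug/mL. Among the measured compounds shown here, the only measured step, a 1.2-fold lower number from compound 1 to compound 2 (0.07 log units; within the scatter), comes from putting methoxy in place of hydrogen on an aromatic carbon; it lies within the scatter, so neither compound can be set above the other, and compound 1 simply stands with compound 2 at the level these two numbers share.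

Compound 3 `COC(=O)C1=C(C)NC(=O)NC1c1ccc(OC)cc1` has not yet been measured. Its difference from compound 1 is methyl in place of hydrogen on an oxygen on an aromatic ring, so the hydroxy of compound 1 becomes methoxy. For the measured compounds named here, the one measured step, from compound 1 to compound 2, is a different change at a different place, so it bears on this step only loosely; what it shows is that a small addition to the aromatic ring left this assay within the scatter. No step beyond the scatter is therefore expected in this assay, in either direction, and the step of a 1.0-fold higher number from compound 1 to compound 3 (0.02 log units; within the scatter) is an estimate resting on that single comparison. Compound 3 is expected to give about 70 ug/mL, between 35 ug/mL and 140 ug/mL.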

Compound 3, half-maximal effective concentration: 206 ug/mL
Compound 3: middle estimate off by 2.9-fold (0.47 log units), on the low side; the whole stated range lies below it.
By their numbers in this assay, from the lowest: compounds 2 and 1 (each within the scatter of the next); then compound 3.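

In this assay, among these compounds, turning the hydroxy of compound 1 into methoxy gives a 3.1-fold higher number from compound 1 to compound 3 (0.49 log units; beyond the scatter), the first step in this short series that lies beyond the scatter. The earlier change, a 1.2-fold lower number from compound 1 to compound 2 (0.07 log units; within the scatter), put a methoxy on an aromatic carbon and kept the hydroxy, so the two steps together show that small additions to this aromatic ring do not all read alike: methyl in place of the hydrogen on the oxygen shifts the effect to larger amounts of compound, while the addition on the carbon stays within the scatter. Nothing given here explains why this one change has an effect that the other lacks.

The compounds shown carry only methyl on this oxygen, so it remains open whether a longer chain such as ethyl there would give a similar step or a different one. Also open, on these data alone, is how this assay reads with an amine or a carboxylic acid in place of the hydroxy, and whether a second methoxy on the ring would matter once the hydroxy has become methoxy.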